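Hydroxyphenyl imine on the aminothiophene core: expected cytotoxicity

This account rests on a few compounds, and the source may have more. Where it says the series, first, only, none or still open, it means among the compounds named here.

Measured compounds:
compound 1 `Nc1sc2c(c1-c1nc3ccccc3s1)CCCC2`, 475 ug/mL
compound 2 `C(=C/c1ccccc1)\C=N\c1sc2c(c1-c1nc3ccccc3s1)CCC2`, 100 ug/mL
compound 3 `Clc1ccccc1/C=N/c1sc2c(c1-c1nc3ccccc3s1)CCCC2`, 407 ug/mL

In an ADME assay on HeLa cells (Homo sapiens) for cytotoxicity, read by MTT assay, with a stated time of 72 h (on this read-out higher numbers stand for lower toxicity in this test and lower numbers for higher toxicity in this test), compound 1 gives the highest of the three numbers. Compound 3 lies nearest to it, and the step of a 1.2-fold lower number from compound 1 to compound 3 (0.07 log units; within the scatter) stays within the scatter. Among the compounds with values here, compound 2 lies furthest away; its value 100 ug/mL sits beyond the scatter from compound 1, but compound 2 differs in more than one place, so no single step is drawn.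

Compound 4 `Oc1ccccc1/C=N/c1sc2c(c1-c1nc3ccccc3s1)CCCC2` is unmeasured. It differs from compound 1 by a group of 9 heavy atoms (7 carbon, 1 nitrogen, 1 oxygen; one six-membered aromatic ring of carbon only) in place of one nitrogen atom, on an aromatic carbon. Within the data shown here, the only step that bears on this change is the one from compound 1 to compound 3, which was within the scatter, so no step beyond the scatter is expected here either. Compound 4 is therefore estimated at 420 ug/mL in this assay, within 240 ug/mL to 650 ug/mL, meaning an expected step of a 1.1-fold lower number from compound 1 to compound 4 (0.05 log units; within the scatter).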

Compound 4, half-maximal cytotoxic concentration: 122 ug/mL
Compound 4: middle estimate off by 3.4-fold (0.54 log units), on the high side; the whole stated range lies above it.
By their numbers in this assay, from the lowest: compounds 2 and 4 (each within the scatter of the next); then compounds 3 and 1 (each within the scatter of the next).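

In this assay, the replacement of amino by the hydroxy-bearing group gives a 3.9-fold lower number from compound 1 to compound 4 (0.59 log units; beyond the scatter), so this change on the aromatic carbon can shift the number beyond the scatter, which the chloro-bearing compound 3 had not shown. Hydroxy in place of chloro on an aromatic carbon gives a 3.3-fold lower number from compound 3 to compound 4 (0.52 log units; beyond the scatter), so the outcome depends on this single substituent and not only on the shared group that replaces amino. Nothing available explains this difference.

The compounds shown leave open whether a methoxy group or an amine in place of hydroxy would give a number closer to that of compound 4 or compound 3.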